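This account rests on a few compounds, and the source may have more. Where it says the series, first, only, none or still open, it means among the compounds named here.

Working notes on the series. The shared core of compound 1 `O=C(O)c1ccc(-c2cnc(C(=O)CCCCCCc3ccccc3)o2)cc1` carries an aryl group on the five-membered aromatic ring; in an assay (Rattus norvegicus) for inhibition of Fatty-acid amide hydrolase 1 (Homo sapiens) (on this read-out lower numbers stand for stronger inhibition and higher numbers for weaker inhibition), compound 1 gives 60 nM. Going by the values given here, compound 2 `COC(=O)c1ccc(-c2cnc(C(=O)CCCCCCc3ccccc3)o2)nc1` is the only other measured member, and in this assay compound 2 gives 3.5 nM. Among the compounds with values here, of the two numbers known so far, compound 1 stands at the higher one, with compound 2 well separated from it beyond the usual scatter.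

The next compound, compound 3 `O=C(CCCCCCc1ccccc1)c1ncc(-c2ncccn2)o1`, differs from compound 1 in one place: pyrimidin-2-yl in place of 4-carboxyphenyl on an aromatic carbon. Within the data shown here, no measured pair differs in exactly this way, so the size of the step has to be guessed from what the two known numbers show. Because compound 2 gives 3.5 nM with a heteroaromatic ring in that position and no free acid, a move in the same direction is expected for compound 3. The step from compound 1 to compound 3 in this assay is estimated at a 12-fold lower number from compound 1 to compound 3 (1.08 log units; beyond the scatter), toward a lower number and beyond the scatter. For compound 3 in this assay the expected value is 5 nM, within a range from 1 nM to 30 nM.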

Compound 3, inhibition constant: 5.3 nM
Beside the measured number, compound 3's estimate is 1.1-fold (0.03 log units) below it, and the stated range covers the measured number.
By their numbers in this assay, from the lowest: compounds 2 and 3 (each within the scatter of the next); then compound 1.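

In this assay, going by these compounds alone, pyrimidin-2-yl in place of 4-carboxyphenyl, on the aromatic carbon next to the ring oxygen, gives a large step (an 11-fold lower number from compound 1 to compound 3 (1.05 log units; beyond the scatter)), the first one-place change at this position with a measured size. The position therefore responds strongly to this swap, and compound 3 at 5.3 nM lies within the scatter of compound 2 at 3.5 nM, so two different heteroaromatic groups without a free acid share this range here. The swap changes the ring, the hydrogen-bond donor and the hydrogen-bond acceptors at once, and no measurement on hand ties the step to any one of these or gives a reason for it.

Still open, on these data alone, is whether the step follows the carboxylic acid or the ring that carries it: a plain phenyl group, or the methyl ester of the 4-carboxyphenyl group, would separate the two. Also open, as far as these compounds go, is how far the result holds with other groups at this position, such as an unsubstituted pyridin-2-yl, or with a shorter or longer chain between the carbonyl and the terminal phenyl.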